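Widening the methoxy of compound 3 to an aryl ether

The compounds below may be only part of what the source reports. "The series", "measured", "known", "first", "only" and "open" are said of these compounds alone.

In a functional assay on MV4-11 cells (Homo sapiens) for antiproliferative activity, read by CCK-8 assay, with a stated time of 72 h (on this read-out lower numbers stand for stronger inhibition and higher numbers for weaker inhibition), compound 3 (`COc1ccc(C(C)(C)O)cc1-c1cn(C)c(=O)c2[nH]c(C(=O)NCc3ccc(C(=O)Nc4ccccc4N)cc3)cc12`) gives 420 nM as the highest number of the three measured. Compound 1 (`CC(C)Oc1ccc(C(C)(C)O)cc1-c1cn(C)c(=O)c2[nH]c(C(=O)NCc3ccc(C(=O)Nc4ccccc4N)cc3)cc12`) at 40 nM and compound 2 (`Cn1cc(-c2cc(C(C)(C)O)ccc2Oc2ccc(F)cc2F)c2cc(C(=O)NCc3ccc(C(=O)NO)cc3)[nH]c2c1=O`) at 190 nM lie lower. Compound 4 (`Cn1cc(-c2cc(C(C)(C)O)ccc2Oc2ccc(F)cc2F)c2cc(C(=O)NCc3ccc(C(=O)Nc4ccccc4N)cc3)[nH]c2c1=O`) follows from compound 3 through 2,4-difluorophenyl in place of methyl on an oxygen on an aromatic ring and this puts 2,4-difluorophenyl in place of methyl on an oxygen on an aromatic ring. Going by the values given here, the one measured step at that oxygen is an 11-fold higher number from compound 1 to compound 3 (1.02 log units; beyond the scatter) and it is large, with methyl in place of isopropyl. Compound 2 carries the same 2,4-difluorophenyl but differs from compound 4 elsewhere. Among the compounds with values here, no measured pair shows this exact change, so the size stays uncertain. The expected step is a 5.3-fold lower number from compound 3 to compound 4 (0.72 log units; beyond the scatter) and so lies beyond the scatter, towards a lower number. For compound 4 the estimate is 80 nM with an expected range from 20 nM to 300 nM as the upper end.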

Compound 4, half-maximal inhibitory concentration: 90 nM
The estimate for compound 4 lay 1.1-fold (0.05 log units) below the measured number; low and high end bracket the measured number.
By their numbers in this assay, from the lowest: compound 1; then compound 4; then compound 2; then compound 3.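

In this assay, an aryl ether on the oxygen on the aromatic ring improves on methyl, with 2,4-difluorophenyl in place of methyl giving the step (a 4.7-fold lower number from compound 3 to compound 4 (0.67 log units; beyond the scatter)), but it does not match isopropyl (a 2.3-fold higher number from compound 1 to compound 4 (0.35 log units; beyond the scatter)). With 2,4-difluorophenyl held fixed, 2-aminophenyl in place of hydroxy on the amide-type nitrogen gives a further step (a 2.1-fold lower number from compound 2 to compound 4 (0.32 log units; beyond the scatter)). No evidence here explains either ordering.

On these data alone, whether a cyclopentyl or an unsubstituted phenyl on that oxygen would track isopropyl or 2,4-difluorophenyl remains open. Also open, as far as these compounds go, is whether the hydroxy to 2-aminophenyl step holds with isopropyl on the oxygen.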